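Anilino variation on the shared core: the iodophenyl analogue

The source may hold more compounds than are shown below. What is called first, only, known or untested is meant among the compounds shown, and "the series" means these compounds.

Compound 1 `COc1cccc(NC2=CC(=O)c3c(nc4n3[C@H]3OC[C@@H](O)[C@H]3OC4)C2=O)c1` reaches only a limit in a functional assay on HeLa cells (Homo sapiens) for inhibition, read by sulforhodamine B assay; a higher number here means a weaker inhibitor, a lower number a stronger inhibitor: compound 1 gives > 8000 nM, a limit rather than a number. Compound 3 `O=C1C(N2CCCC2)=CC(=O)c2c1nc1n2[C@H]2OC[C@@H](O)[C@H]2OC1` likewise stops at a limit; in this assay compound 3 gives > 16000 nM. For the measured compounds named here, the only step touching compound 1, a step that the two limits leave unreadable from compound 1 to compound 3, therefore cannot be sized, both values sitting at limits (the limit of > 8000 nM in this assay, at which 1 of the 3 values shown sits, (the limit of > 16000 nM in this assay, at which 1 of the 3 values shown sits)). Going by the values given here, compound 2 `O=C1C=C(Nc2cccc(Cl)c2)C(=O)c2c1nc1n2[C@H]2OC[C@@H](O)[C@H]2OC1` is the sole measured member with a number; in this assay compound 2 gives 6040 nM. Compound 4 `O=C1C(Nc2ccc(I)cc2)=CC(=O)c2c1nc1n2[C@H]2OC[C@@H](O)[C@H]2OC1` differs from compound 1 by 4-iodophenyl in place of 3-methoxyphenyl on an amine nitrogen. Among the compounds with values here, no measured step covers an exchange of one aryl group for another on this amine nitrogen, so the direction is open. Compound 4 is expected near 7000 nM, within 2500 nM to 20000 nM. The implied step an at least 1.1-fold lower number from compound 1 to compound 4 (0.05 log units; that floor lies within the scatter) is expected to stay unreadable against the limit of compound 1.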

Compound 4, half-maximal inhibitory concentration: 4010 nM
The estimate for compound 4 lay 1.7-fold (0.24 log units) above the measured number, within the range that was stated.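

Replacing pyrrolidin-1-yl with (4-iodophenyl)amino gives, in this assay, an at least 3.9-fold lower number from compound 3 to compound 4 (0.60 log units; beyond the scatter), so this double-bonded ring carbon now has a step beyond the scatter, though only as a floor. Exchanging the aryl group on the amine nitrogen gives an at least 1.9-fold lower number from compound 1 to compound 4 (0.29 log units; that floor lies within the scatter), which sets no order between 3-methoxyphenyl and 4-iodophenyl. That step remains a floor because compound 1 stands at a limit: the limit of > 8000 nM in this assay, at which 1 of the 4 values shown sits.

Still open, on these data alone, is how a 4-fluorophenyl or 4-aminophenyl group on this amine nitrogen would read in this assay.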